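This account rests on a few compounds, and the source may have more. Where it says the series, first, only, none or still open, it means among the compounds named here.

Compound 1 `CCN1CCC(CC(=O)NC2(c3ccc(Cl)c(Cl)c3)C(=O)Nc3cc(Cl)cc(Cl)c32)CC1`: 1 nM
Compound 2 `CN1CCN(CC(=O)N[C@]2(c3ccc(Cl)cc3)C(=O)Nc3cc(Cl)c(Cl)cc32)CC1`: 47 nM
Compound 3 `CN1CCN(CC(=O)NC2(c3ccc(Cl)c(Cl)c3)C(=O)Nc3cc(Cl)ccc32)CC1`: 111 nM

Of the compounds shown here, three built on one shared core have been measured in an in vitro functional assay on CHO-CREluc cells for antagonist activity at growth hormone secretagogue receptor type 1 (Homo sapiens), read by a luciferase reporter, with a stated time of 4 h; a higher number here means a weaker inhibitor, a lower number a stronger inhibitor. Compound 1 gives 1 nM, the lowest of the three numbers, which makes it the strongest inhibitor of the set. Compound 2 gives 47 nM and compound 3 gives 111 nM; both lie far beyond the scatter from compound 1. Each of them, however, differs from compound 1 in more than one place at once, so neither pair shows what any single change does.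

Compound 4 `CCN1CCCC(CC(=O)NC2(c3ccc(Cl)c(Cl)c3)C(=O)Nc3cc(Cl)cc(Cl)c32)C1` differs from compound 1 in exactly one place: 1-ethylpiperidin-3-yl in place of 1-ethylpiperidin-4-yl on a saturated chain carbon bound to a carbonyl carbon. The same atoms are present in both, joined differently, so only the point where the ring meets the chain carbon bound to the carbonyl carbon has moved.

Going by the values given here, no measured pair shows a change of this kind, so the size of the step rests on judgement. Rearrangements that keep every atom but move one attachment point often weaken a compound somewhat without destroying it. The expected step is a 3.0-fold higher number from compound 1 to compound 4 (0.48 log units; beyond the scatter), a modest loss that would just reach beyond the scatter. Compound 4 is therefore estimated at 3 nM, with a range from 1 nM to 15 nM.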

Compound 4, half-maximal inhibitory concentration: 47 nM
Beside the measured number, compound 4's estimate is 16-fold (1.19 log units) below it; the whole stated range lies below it.
By their numbers in this assay, from the lowest: compound 1; then compounds 2 and 4 (each within the scatter of the next); then compound 3.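

In this assay moving only the point where the ring meets the chain gives a 47-fold higher number from compound 1 to compound 4 (1.67 log units; beyond the scatter) and so counts as a large step, even though 1-ethylpiperidin-3-yl and 1-ethylpiperidin-4-yl contain exactly the same atoms. This place, on a saturated chain carbon bound to a carbonyl carbon, is therefore sensitive to how the ring is attached and not only to which atoms are present, something compound 2 and compound 3 could not show, as each differs from compound 1 in more than one place at once. Nothing given here explains why this one shift in attachment weakens the compound so much.

From the compounds shown here alone, what remains open is whether the sensitivity belongs to the ring attachment alone or would also appear with other groups at this place, such as 1-ethylpyrrolidin-3-yl, with its smaller ring, or an open-chain diethylamino group. Going by these compounds, it is also open whether the same shift would cost as much on a core carrying a different pattern of chlorine atoms.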